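Chain Extension at the Hydroxamate End of Compound 2

The source may hold more compounds than are shown below. What is called first, only, known or untested is meant among the compounds shown, and "the series" means these compounds.

Working notes on a set of macrocyclic hydroxamates built on one shared core. Compound 1 `O=C(CCCCC(=O)N1C/C=C/CCOc2cccc(c2)-c2ccnc(n2)Nc2cccc(c2)C1)NO`, compound 2 `O=C(CCCCCCC(=O)N1C/C=C/COCc2cccc(c2)-c2ccnc(n2)Nc2cccc(c2)C1)NO` and compound 3 `O=C(CCCCCCN1C/C=C/COCc2cccc(c2)-c2ccnc(n2)Nc2cccc(c2)C1)NO` have been measured in a functional assay on HL-60 cells (Homo sapiens) for inhibition, read by CellTiter-Glo, with a stated time of 48 h; a lower number here means a stronger inhibitor of growth, a higher number a weaker inhibitor of growth. In this assay compound 1 gives 1270 nM. Among the measured compounds shown here, compound 2 gives 2870 nM, the highest of the three numbers so far, with compound 1 nearer to it and compound 3 furthest away. Compound 3 gives 900 nM, the lowest number of the three.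

Compound 4 `O=C(CCCCCCCC(=O)N1C/C=C/COCc2cccc(c2)-c2ccnc(n2)Nc2cccc(c2)C1)NO` is the next member and differs from compound 2 in one place: (hydroxycarbamoyl)methyl in place of hydroxycarbamoyl on a saturated chain carbon, six bonds along the chain from a carbonyl carbon. For the measured compounds named here, the only single-change step measured so far is a 3.2-fold lower number from compound 2 to compound 3 (0.50 log units; beyond the scatter), which concerns the carbonyl on the ring nitrogen rather than the chain that carries the hydroxycarbamoyl group, so it does not bear directly on the change in hand. Compound 1 differs from compound 2 in more than one place, so its value cannot be assigned to chain length alone. Going by the values given here, with no comparable step available, the expectation is a number close to that of compound 2, not beyond the scatter. The estimate for compound 4 in this assay is 2500 nM, with a range from 1000 nM to 6500 nM. This corresponds to an expected step of a 1.1-fold lower number from compound 2 to compound 4 (0.06 log units; within the scatter).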

Compound 4, concentration for 50% growth inhibition: 1660 nM
Beside the measured number, compound 4's estimate is 1.5-fold (0.18 log units) above it, within the range that was stated.
By their numbers in this assay, from the lowest: compounds 3, 1, 4 and 2 (each within the scatter of the next, the first and the last beyond it).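

Among the compounds shown here, replacing hydroxycarbamoyl with (hydroxycarbamoyl)methyl on a saturated chain carbon, six bonds along the chain from a carbonyl carbon, gives the first single-change reading at the hydroxamate end of the chain: in this assay the result is a 1.7-fold lower number from compound 2 to compound 4 (0.24 log units; within the scatter) and the change cannot be told apart from repeat variation. For the compounds shown here, the position therefore accepts the longer group on this core without a distinguishable shift in the growth-inhibition number, whereas the earlier single-change step at the ring nitrogen, a 3.2-fold lower number from compound 2 to compound 3 (0.50 log units; beyond the scatter), remains the only step on compound 2 that is beyond the scatter. Compound 1 differs from compound 4 in more than one place, so it adds nothing to the reading of chain length.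

Still open, as far as these compounds go, is whether a longer chain, such as 3-(hydroxycarbamoyl)propyl in place of hydroxycarbamoyl at this position, or a carboxylic acid at the chain end, would move the number beyond the scatter, and whether the chain of compound 4 behaves the same way on a ring nitrogen without the carbonyl. No measurement in hand accounts for the reading at this position.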